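The source may hold more compounds than are shown below. What is called first, only, known or untested is meant among the compounds shown, and "the series" means these compounds.

Within the data shown here, compound 3 `COc1cc(-c2nn(-c3cccc(NC(=O)Nc4cccc(C(F)(F)F)c4)c3)cc2-c2ccncc2)ccc1Cl` stands second highest of the three numbers so far: in a functional assay on MDA-MB-231 cells (Homo sapiens) for inhibition, read by sulforhodamine B assay, with a stated time of 48 h (a lower number here means a stronger inhibitor of growth, a higher number a weaker inhibitor of growth), compound 3 gives 2370 nM, close to compound 2 `COc1cc(-c2nn(-c3cccc(NC(=O)Nc4ccc(Cl)c(Cl)c4)c3)cc2-c2ccncc2)ccc1Cl`, which gives 1920 nM, and well apart from compound 1 `COc1cc(-c2nn(-c3cccc(NC(=O)c4cccc(C(F)(F)F)c4)c3)cc2-c2ccncc2)ccc1Cl`, which gives 9960 nM. Compound 4 `COc1cc(-c2nn(-c3cccc(NC(=O)c4ccc(Cl)c(C(F)(F)F)c4)c3)cc2-c2ccncc2)ccc1Cl` differs from compound 3 by 4-chloro-3-(trifluoromethyl)phenyl in place of (3-(trifluoromethyl)phenyl)amino on a carbonyl carbon. Among the measured compounds shown here, two measured steps bear on this: the change a 4.2-fold lower number from compound 1 to compound 3 (0.62 log units; beyond the scatter), and the change a 1.2-fold higher number from compound 2 to compound 3 (0.09 log units; within the scatter). Going from compound 3 to compound 4 reverses the first kind of change while adding a chlorine, so a rise of roughly the size seen between compound 1 and compound 3 is expected. The expected step is a 3.0-fold higher number from compound 3 to compound 4 (0.47 log units; beyond the scatter). Compound 4 is therefore estimated at 7000 nM, within 2500 nM to 20000 nM.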

Compound 4, concentration for total growth inhibition: > 32500 nM
Compound 4 ended at the assay's limit; the forecaster's own chance of this, stated with the estimate: 5%; at least 4.6-fold (0.66 log units) between middle value and limit.
By their numbers in this assay, from the lowest: compounds 2 and 3 (each within the scatter of the next); then compound 1. At a limit, above all of these: compound 4.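

In this assay compound 4 ends at a limit and not at a number: the limit of > 32500 nM in this assay, at which 1 of the 4 values shown sits. On the ring of the amide, chloro in place of hydrogen on an aromatic carbon weakens growth inhibition further, with an at least 3.2-fold higher number from compound 1 to compound 4 (0.51 log units; beyond the scatter). Losing the amino link on the carbonyl carbon and adding this chloro together give an at least 13-fold higher number from compound 3 to compound 4 (1.13 log units; beyond the scatter) and an at least 16-fold higher number from compound 2 to compound 4 (1.22 log units; beyond the scatter), both large steps. As far as these compounds go, whether chloro has the same effect where the amino link is kept remains open. So does whether a methyl or a methoxy in place of that chloro would be tolerated.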